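Switching the pendant ring: compound 2 to compound 3

The compounds below may be only part of what the source reports. "The series", "measured", "known", "first", "only" and "open" are said of these compounds alone.

Going by the values given here, compound 2 `c1ccc(-c2cc[nH]n2)c(OCC2=NCCN2)c1` gives 79.4 nM in a functional assay for activation of Alpha-1B adrenergic receptor (Homo sapiens), read by calcium flux (a higher number here means that more compound is needed for the effect, a lower number that less compound is needed), the higher of the two numbers measured so far. Its nearest neighbour is compound 1 `c1ccc(-c2ccoc2)c(OCC2=NCCN2)c1`, which in this assay gives 5.01 nM. Among the compounds with values here, the single measured step, a 16-fold higher number from compound 1 to compound 2 (1.20 log units; beyond the scatter), is the only comparison that bears on the present change. Compound 3 `Cc1ccoc1-c1ccccc1OCC1=NCCN1` has not yet been measured in this assay; relative to compound 2 the change is 3-methylfuran-2-yl in place of 1H-pyrazol-3-yl on an aromatic carbon. This broadly reverses the earlier step, although the furan now enters as 3-methylfuran-2-yl rather than furan-3-yl, so the earlier step is a guide rather than a template. A large drop in this assay is therefore expected for compound 3, on the order of a 9.9-fold lower number from compound 2 to compound 3 (1.00 log units; beyond the scatter). The estimate for compound 3 in this assay is 8 nM, with a range from 2 nM to 40 nM.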

Compound 3, half-maximal effective concentration: < 100000 nM
Compound 3 was reported as a limit; the forecaster's own chance of this, stated with the estimate: 2%; the middle value is on the limit's open side.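

In this assay compound 3 carries only the limit < 100000 nM and no number, so the steps to it from compound 1 and from compound 2 cannot be read. Left open is whether 3-methylfuran-2-yl, in place of furan-3-yl or 1H-pyrazol-3-yl, shifts the number at all.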